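The source may report more compounds than this note shows. Statements on the series, on what has been measured and on what is new or still open speak of the compounds shown alone.

Compound 2 `CC1(C)Oc2ccccc2[C@@H](/N=C(\NC#N)Nc2ccccc2)[C@@H]1O` stands alone with one number in a functional assay (aorta) for inhibition, with Rattus norvegicus as the target (a higher number here means a weaker inhibitor, a lower number a stronger inhibitor), where compound 2 gives 72700 nM; a further test of it left no number. Compound 1 `CC1(C)Oc2ccc(C#N)cc2[C@@H](/N=C(\NC#N)Nc2ccccc2)[C@@H]1O`, which carries a nitrile, gives lower values in this assay, as seen in the several entries of compound 1 in this assay, 1400 nM; 4200 nM; 1300 nM (3 entries), and in this assay compound 1 gives 1400 nM; 4200 nM; 1300 nM (3 entries). Compound 3 `CC1(C)Oc2ccc([N+](=O)[O-])cc2[C@@H](/N=C(\NC#N)Nc2ccccc2)[C@@H]1O` arises from compound 2 by nitro in place of hydrogen on an aromatic carbon. For the measured compounds named here, no measured step joins any two compounds here. The expected step of a 29-fold lower number from compound 2 to compound 3 (1.46 log units; beyond the scatter) is a large gain in potency. That expectation rests on compound 1 reaching (the several entries of compound 1 in this assay, 1400 nM; 4200 nM; 1300 nM (3 entries)). Compound 3 is estimated at 2500 nM, within 600 nM to 12000 nM.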

Compound 3, half-maximal inhibitory concentration: 2000 nM
Compound 3: middle estimate off by 1.3-fold (0.10 log units), on the high side; the measured number falls inside the stated range.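

For the compounds shown here, this is the first measured step in the set: in this assay, nitro in place of hydrogen on an aromatic carbon gives a 36-fold lower number from compound 2 to compound 3 (1.56 log units; beyond the scatter). The large gain at this position is therefore not confined to the nitrile of compound 1, since a second group reaches the same range. Compound 3 gives 2000 nM, which lies among the entries of compound 1: the several entries of compound 1 in this assay, 1400 nM; 4200 nM; 1300 nM (3 entries).

The compounds shown leave open whether an amine or a carboxylic acid on the same carbon would give a similar gain. They also cannot tell what nitro and nitrile have in common that produces it.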